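Swapping a methylphenyl for a hydroxyphenyl on the triazole

The source may hold more compounds than are shown below. What is called first, only, known or untested is meant among the compounds shown, and "the series" means these compounds.

Three esters and acids of one shared core were tested in a functional assay on A549 cells (Homo sapiens) for antiproliferative activity, read by MTT assay, with a stated time of 48 h; a lower number here means a stronger inhibitor, a higher number a weaker inhibitor. Compound 1 `C/C(=C\CC/C(C)=C/CC[C@@H]1[C@@]2(C)CCC(=O)C(C)(C)[C@H]2CC[C@@]1(C)O)CC/C=C(\C)C(=O)OCc1cn(-c2ccccc2C)nn1` carries a 2-methylphenyl on its triazole, and it gives only a limit of > 150000 nM. The free acid compound 3 `C/C(=C\CC/C(C)=C/CC[C@@H]1[C@@]2(C)CCC(=O)C(C)(C)[C@H]2CC[C@@]1(C)O)CC/C=C(\C)C(=O)O` likewise reaches only the limit of > 150000 nM. Only compound 2 `C/C(=C\CC/C(C)=C/CC[C@@H]1[C@@]2(C)CCC(=O)C(C)(C)[C@H]2CC[C@@]1(C)O)CC/C=C(\C)C(=O)OCc1cn(C[C@@H]2O[C@H](n3ccc(=O)[nH]c3=O)[C@H]3OC(C)(C)O[C@H]32)nn1` gives a number, 15300 nM, so compound 1 sits together with compound 3 at the weak end (the limit of > 150000 nM in this assay, at which 2 of the 3 values shown sit). Compound 4 `C/C(=C\CC/C(C)=C/CC[C@@H]1[C@@]2(C)CCC(=O)C(C)(C)[C@H]2CC[C@@]1(C)O)CC/C=C(\C)C(=O)OCc1cn(-c2cccc(O)c2)nn1` differs from compound 1 by 3-hydroxyphenyl in place of 2-methylphenyl on an aromatic nitrogen. Going by the values given here, with no measured step of this kind, the expected change is uncertain, and compound 4 may well stay at the limit. Still, a modest move toward stronger inhibition is estimated, from compound 1 to compound 4 of an at least 1.8-fold lower number from compound 1 to compound 4 (0.27 log units; that floor lies within the scatter). Compound 4 is expected to give about 80000 nM, between 20000 nM and 200000 nM.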

Compound 4, half-maximal inhibitory concentration: 42800 nM
Compound 4: the middle estimate sits 1.9-fold (0.27 log units) above what was measured; the range from low to high includes it.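

In this assay the group on the triazole nitrogen responds to change, with an at least 3.5-fold lower number from compound 1 to compound 4 (0.54 log units; beyond the scatter) on going from 2-methylphenyl to 3-hydroxyphenyl. A phenyl group on the triazole can therefore give a real number, which compound 1 did not. That size is only a floor, because compound 1 stands at a limit: the limit of > 150000 nM in this assay, at which 2 of the 4 values shown sit.

The swap changes both the group and its place on the ring, and the compounds shown cannot separate the two. Also open, on these data alone, is how 2-hydroxyphenyl, 3-methylphenyl or 3-aminophenyl would behave here.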